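The compounds below may be only part of what the source reports. "The series", "measured", "known", "first", "only" and "open" are said of these compounds alone.

Compound 1: `OC1C[C@@H]2CCCC[C@@H]2[C@H]1/C=C/c1ccc(-c2cccc(F)c2)cn1`; 220 nM
Compound 2: `NC1C[C@@H]2CCCC[C@@H]2[C@H]1/C=C/c1ccc(-c2cccc(F)c2)cn1`; 230 nM

Both values come from an assay on cell membranes for displacement of a labelled ligand from proteinase-activated receptor 1 (Homo sapiens), read by scintillation counting, with a stated time of 60 min; on this read-out lower numbers stand for stronger inhibition and higher numbers for weaker inhibition. Compound 1 and compound 2 lie within the scatter of each other, so neither can be placed above the other; compound 1 is simply one of two closely matched numbers. Within the data shown here, the only measured step, a 1.0-fold higher number from compound 1 to compound 2 (0.02 log units; within the scatter), exchanges amino for hydroxy and leaves the rest untouched.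

Compound 3, `CC1(O)C[C@@H]2CCCC[C@@H]2[C@H]1/C=C/c1ccc(-c2cccc(F)c2)cn1`, differs from compound 1 by methyl in place of hydrogen on a saturated ring carbon. Among the measured compounds shown here, no measured step alters this carbon in this way, so the single step on record bears on it only indirectly: it shows that the core of compound 1 accepted a change at that ring position without a shift beyond the scatter. On that basis a step of a 1.4-fold higher number from compound 1 to compound 3 (0.13 log units; within the scatter) is expected in this assay, with no clear direction. Compound 3 is therefore estimated at 300 nM, within 120 nM to 900 nM.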

Compound 3, half-maximal inhibitory concentration: 33 nM
Estimate against measurement, compound 3: 9.1-fold (0.96 log units) above; measured number below the stated range.
By their numbers in this assay, from the lowest: compound 3; then compounds 1 and 2 (each within the scatter of the next).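

In this assay, methyl in place of hydrogen on this saturated ring carbon, next to the ring atom that bears a large group, gives a 6.7-fold lower number from compound 1 to compound 3 (0.82 log units; beyond the scatter). The position therefore responds to substitution, which the earlier exchange of amino for hydroxy on the same carbon, a 1.0-fold higher number from compound 1 to compound 2 (0.02 log units; within the scatter), did not reveal: that swap stayed within the scatter, whereas adding methyl while keeping the hydroxy moves the number beyond it. Nothing available explains why this methyl lowers the number.

The compounds shown leave open whether an ethyl group or a longer chain on this carbon would lower the number further or lose the step. They also leave open whether methyl would give a similar step alongside the amino group of compound 2.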